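Benzofuran sulfonamides in colon carcinoma cells: notes before compound 4

The compounds below may be only part of what the source reports. "The series", "measured", "known", "first", "only" and "open" are said of these compounds alone.

Measured so far:
compound 1, `CCOC(=O)c1oc2ccc(N(Cc3ccccc3)S(=O)(=O)c3cccc(Cl)c3)cc2c1C`, > 40000 nM
compound 2, `CCOC(=O)c1oc2ccc(N(Cc3ccccc3)S(=O)(=O)c3ccccc3)cc2c1C`, > 40000 nM
compound 3, `Cc1c(C(=O)NCCCn2ccnc2)oc2ccc(N(Cc3ccccc3)S(=O)(=O)c3ccc(Cl)cc3)cc12`, 5000 nM

The read-out throughout is a functional assay on HCT-116 cells (Homo sapiens) for inhibition, read by MTT assay, with a stated time of 72 h; a lower number here means a stronger inhibitor, a higher number a weaker inhibitor. Compound 1 gives > 40000 nM, which is a limit of the assay and not a number. Compound 2 likewise gives > 40000 nM, again a limit. Going by the values given here, of the three values, only that of compound 3 is a number; the other two sit at the limit of > 40000 nM in this assay, at which 2 of the 3 values shown sit.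

From compound 2 to compound 1 the change is chloro in place of hydrogen on an aromatic carbon, and the step it produced is a step that the two limits leave unreadable from compound 2 to compound 1. How the core of compound 3 differs from that of compound 2 is not broken down here.

The unmeasured compound 4, `Cc1c(C(=O)NCCCn2ccnc2)oc2ccc(N(Cc3ccc(Cl)cc3)S(=O)(=O)c3ccc(Cl)cc3)cc12`, differs from compound 3 by chloro in place of hydrogen on an aromatic carbon. This is the same kind of change as that from compound 2 to compound 1, but the place is not identical: there the chloro enters meta to a large group on the phenylsulfonyl, here para to a large group on the benzyl. Since both measured values around the earlier step are limits, no size can be carried over from it.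

The expectation for compound 4 therefore rests only on the value of compound 3, 5000 nM, and on the smallness of the change: the expected step is a 1.3-fold lower number from compound 3 to compound 4 (0.10 log units; within the scatter), within the usual scatter. Compound 4 is estimated at 4000 nM, expected between 1500 nM and 12000 nM.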

Compound 4, half-maximal inhibitory concentration: 1890 nM
For compound 4 the middle estimate is 2.1-fold (0.33 log units) above the measured one; measured number inside the range.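

In this assay the change from benzyl to 4-chlorobenzyl gives a 2.6-fold lower number from compound 3 to compound 4 (0.42 log units; beyond the scatter), a modest step that holds for this one core and this one place on it. The same kind of change on the core of compound 2, chloro in place of hydrogen on an aromatic carbon, cannot be read, and no size can be set beside the new step: the limit of > 40000 nM in this assay, at which 2 of the 4 values shown sit. What the series shows is therefore a single readable step, which establishes that chloro can lower the number on the core of compound 3 but not that the change carries from one core to another, or from one aromatic ring of these compounds to the other.

The compounds shown leave open what 4-chlorobenzyl does on a core carrying the ethyl ester, and whether fluoro, methoxy or trifluoromethyl in place of the chloro would give a step of similar size. They also leave open how far the number depends on the amide side chain shared by compound 3 and compound 4, where a longer chain, a simple amine or a carboxylic acid would test that dependence.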